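Ethyl for Methyl in a Rat Inhibition Series

The source may hold more compounds than are shown below. What is called first, only, known or untested is meant among the compounds shown, and "the series" means these compounds.

Compound 1, `CC1CC/C(=N\Nc2ccc(F)cc2)c2ncc(C(=O)O)c(=O)n21`: > 1000 umol/kg
Compound 2, `Cc1ccc(N/N=C2\CCC(C)n3c2ncc(C(=O)O)c3=O)cc1`: > 1000 umol/kg

Compound 1 `CC1CC/C(=N\Nc2ccc(F)cc2)c2ncc(C(=O)O)c(=O)n21` and compound 2 `Cc1ccc(N/N=C2\CCC(C)n3c2ncc(C(=O)O)c3=O)cc1` share one core and were both tested in a functional assay on the whole organism for inhibition, with Rattus norvegicus as the target; a higher number here means that more compound is needed for the effect, a lower number that less compound is needed. In this assay compound 1 gives > 1000 umol/kg, which is a limit of the assay rather than a number. In this assay compound 2 gives > 1000 umol/kg, again a limit. The step between them is a step that the two limits leave unreadable from compound 1 to compound 2. Compound 2 thus stands at the limit of > 1000 umol/kg in this assay, at which 2 of the 2 values shown sit, and nothing more precise can be said of where it sits.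

Compound 3 `CCc1ccc(N/N=C2\CCC(C)n3c2ncc(C(=O)O)c3=O)cc1` differs from compound 2 by methyl in place of hydrogen on a saturated chain carbon bound to an aromatic carbon. Among the compounds with values here, the only measured step offers no readable size, so it gives neither a direction nor a magnitude to carry over to this change. The expectation is simply that compound 3 stays near the same limit. Compound 3 is therefore estimated at 1500 umol/kg, with a range from 400 umol/kg to 6000 umol/kg, meaning an expected step that the limit leaves unreadable from compound 2 to compound 3.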

Compound 3, dose for 50% inhibition: > 1000 umol/kg
Compound 3 was reported as a limit (the forecaster's own chance of this, stated with the estimate: 85%); the middle value is on the limit's open side.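

Compound 3 gives > 1000 umol/kg in this assay, which is again a limit of the assay, so no step can be read among compound 1, compound 2 and compound 3. The compounds shown leave open how much of each is actually needed and whether fluoro, methyl or ethyl makes any difference, because all three share one result: the limit of > 1000 umol/kg in this assay, at which 3 of the 3 values shown sit.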